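This account rests on a few compounds, and the source may have more. Where it says the series, first, only, none or still open, it means among the compounds named here.

Compound 1, `Cc1cccc(C)c1-c1cccc(COc2ccc(CCC(=O)O)cc2)c1`, gives 6.7 nM in a functional assay on CHO cells for agonist activity at Free fatty acid receptor 1 (Homo sapiens), read by calcium flux; a higher number here means that more compound is needed for the effect, a lower number that less compound is needed.
Compound 2, `Cc1cccc(C)c1-c1cccc(COc2ccc(CCC(=O)O)c(C)n2)c1`, gives 81 nM.
Compound 3, `Cc1cccc(C)c1-c1cccc(COc2ccc(CC(C)C(=O)O)cn2)c1`, gives 65 nM.

Among these three numbers compound 3 stands second highest. Its number and that of compound 2 lie within the usual scatter of each other, so no order between them can be read; compound 1 lies far from both, beyond the scatter, with the lowest number of the set.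

Compound 4, `Cc1cccc(C)c1-c1cccc(COc2ccc(C(C)CC(=O)O)cn2)c1`, is not yet measured. It differs from compound 3 by 1-(carboxymethyl)ethyl in place of 2-carboxypropyl on an aromatic carbon. For the measured compounds named here, no measured pair shows this same change, so its size is unknown. The expected step from compound 3 to compound 4 in this assay is small and not clearly beyond the scatter: a 1.1-fold higher number from compound 3 to compound 4 (0.03 log units; within the scatter). Compound 4 is therefore estimated at 70 nM, with a range from 25 nM to 200 nM.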

Compound 4, half-maximal effective concentration: 10 nM
For compound 4 the middle estimate is 7.0-fold (0.85 log units) above the measured one; measured number below the stated range.
By their numbers in this assay, from the lowest: compounds 1 and 4 (each within the scatter of the next); then compounds 3 and 2 (each within the scatter of the next).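

Compound 3 and compound 4 hold the same atoms, joined differently, yet in this assay placing 1-(carboxymethyl)ethyl where 2-carboxypropyl stood gives a 6.5-fold lower number from compound 3 to compound 4 (0.81 log units; beyond the scatter). For the compounds shown here, at this aromatic carbon, then, the way the chain is joined matters and not only which atoms it contains, something no earlier pair could show. Nothing measured here gives a reason for this step. Still open, from the compounds shown here alone, is how the number would move with an ethyl group as the branch on this chain, or with a tetrazole ring in place of the carboxylic acid.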